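The compounds below may be only part of what the source reports. "The series", "measured", "known", "first", "only" and "open" are said of these compounds alone.

Measured so far:
compound 1 `C[C@H](NC(=O)CN(c1nc(Cl)nc2c1ncn2C1CCCCO1)C1CC1)C(=O)OCc1ccccc1` gives 32.1% in a functional assay on the whole organism with Mus musculus as the target, with a stated time of 90 min, at a dose of 25 umol/kg by the oral route; on this read-out lower numbers stand for a weaker effect and higher numbers for a stronger effect at the one dose given
compound 2 `CC(C)(C)OC(=O)NCCCC[C@H](NC(=O)CN(c1nc(Cl)nc2c1ncn2C1CCCCO1)C1CC1)C(=O)OCc1ccccc1` gives 32.9% in this assay

In this assay compound 2 stands highest of the two numbers, with compound 1 nearest and within the scatter. Compound 3 `CSCC[C@H](NC(=O)CN(c1nc(Cl)nc2c1ncn2C1CCCCO1)C1CC1)C(=O)OCc1ccccc1` is not yet measured; its change from compound 2 is methylsulfanyl in place of 2-((tert-butoxycarbonyl)amino)ethyl on a saturated chain carbon, three bonds along the chain from an amide-type nitrogen and a carbonyl carbon. For the measured compounds named here, the only step available is a number 0.8 percentage points higher from compound 1 to compound 2 (within the scatter), which touches the same chain but adds rather than exchanges a group, so it bears on the change only loosely. No step beyond the scatter is therefore expected, and compound 3 is estimated at 32% (range 18% to 46%), a step of a number 0.9 percentage points lower from compound 2 to compound 3 (within the scatter) expected.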

Compound 3, a percentage reported as activity, at one dose (the size of the read-out at that dose, not a potency): 42.7%
Compound 3: middle estimate off by 10.7 percentage points, on the low side, within the range that was stated.
By their numbers in this assay, from the lowest: compounds 1, 2 and 3 (each within the scatter of the next, the first and the last beyond it).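

In this assay, for the compounds shown here, the (methylsulfanyl)methyl group on the saturated chain carbon gives the first step at this position that clears the scatter, with a number 10.6 percentage points higher from compound 1 to compound 3 (beyond the scatter) as its size. The exchange of 2-((tert-butoxycarbonyl)amino)ethyl for methylsulfanyl reads as a number 9.8 percentage points higher from compound 2 to compound 3 (within the scatter) and so does not separate the two side chains. Nothing at hand explains either step.

Open, on these data alone, is whether a free amine or a carboxylic acid at the end of this chain would keep that level. A plain butyl chain would show whether the sulfur is needed at all.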